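The source may report more compounds than this note shows. Statements on the series, on what has been measured and on what is new or still open speak of the compounds shown alone.

Going by the values given here, compound 3 `Cc1ccc(NC(=O)CCCCCCCSc2nnc(Cc3nn(C)c(=O)c4ccccc34)n2C)c(Cl)c1` gives 2300 nM in an assay on isolated protein (Mus musculus) for inhibition of IL15-IL15 receptor (Homo sapiens), read by resazurin assay, with stated times of 30 min and 2.5 days (a lower number here means a stronger inhibitor, a higher number a weaker inhibitor), the highest of the three numbers measured so far. Compound 1 `Cn1c(Cc2nn(C)c(=O)c3ccccc23)nnc1SCCCCCCCC(=O)Nc1ccc(Cl)cc1Cl` gives 1900 nM, and the step of a 1.2-fold higher number from compound 1 to compound 3 (0.08 log units; within the scatter) stays within the scatter. Compound 2 `Cn1c(Cc2nn(C)c(=O)c3ccccc23)nnc1SCCCCCCCC(=O)Nc1ccc(Cl)cc1` gives 800 nM; the step of a 2.9-fold higher number from compound 2 to compound 3 (0.46 log units; beyond the scatter) is a modest one beyond the scatter, as is a 2.4-fold lower number from compound 1 to compound 2 (0.38 log units; beyond the scatter). Compound 4 `Cn1c(Cc2nn(C)c(=O)c3ccccc23)nnc1SCCCCCCCC(=O)Nc1ccc(O)cc1O` has not yet been measured. It differs from compound 3 in a single place: 2,4-dihydroxyphenyl in place of 2-chloro-4-methylphenyl on an amide-type nitrogen. Among the compounds with values here, the measured steps bear on it only in part: the loss of the chloro in a 2.4-fold lower number from compound 1 to compound 2 (0.38 log units; beyond the scatter) and the exchange of methyl for chloro in a 1.2-fold higher number from compound 1 to compound 3 (0.08 log units; within the scatter) show that swaps on this ring shift the number modestly or not at all, but no measured compound carries a hydroxyl on the ring entering here, so the direction remains open. Compound 4 is therefore expected to give an estimated 1500 nM, within a range from 500 nM to 5000 nM. For compound 4 the expected step is a 1.5-fold lower number from compound 3 to compound 4 (0.19 log units; within the scatter), estimated to stay close to the scatter.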

Compound 4, half-maximal inhibitory concentration: 17000 nM
Beside the measured number, compound 4's estimate is 11-fold (1.05 log units) below it; the whole stated range lies below it.
By their numbers in this assay, from the lowest: compound 2; then compounds 1 and 3 (each within the scatter of the next); then compound 4.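

In this assay the group on the amide-type nitrogen proves able to shift the number far more than the chloro and methyl swaps suggested, with a 7.4-fold higher number from compound 3 to compound 4 (0.87 log units; beyond the scatter) and an 8.9-fold higher number from compound 1 to compound 4 (0.95 log units; beyond the scatter) and then a 21-fold higher number from compound 2 to compound 4 (1.33 log units; beyond the scatter) as the large step of the three. All three steps are beyond the scatter, which makes compound 4 the weakest of the four, and its 2,4-dihydroxyphenyl group brings hydrogen-bond donors and acceptors where 2-chloro-4-methylphenyl has none. Nothing available here accounts for this loss.

The compounds shown leave open whether one hydroxyl alone would give the same loss or whether both are needed. They also leave open how methoxy or an amine in place of the hydroxyls on this ring would read.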